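Quaternary head groups on the chain: compound 3 toward compound 4

A few compounds are considered here, and "the series" means these few. Any claim that something is new, unique, unknown or untested is made for them only; others in the source may bear on it.

Three compounds sharing one core differ only in the charged group at the end of the chain. Compound 1 `Cc1cc(-n2cc(C(=O)Nc3cc(F)cc(F)c3)c(=O)c3ccc(N(C)C)nc32)ccc1OCCCCCCC[N+]12CCN(CC1)CC2` gives 20.8% in an assay on LX2 cells for inhibition of COL1A1 promoter (Homo sapiens), read by a luciferase reporter, with a stated time of 24 h, tested at 50 uM; on this read-out higher numbers stand for a stronger effect at the one concentration tested and lower numbers for a weaker effect. Compound 2 `Cc1cc(-n2cc(C(=O)Nc3cc(F)cc(F)c3)c(=O)c3ccc(N(C)C)nc32)ccc1OCCCCCCC[n+]1ccccc1` gives 55%, and compound 3 `Cc1cc(-n2cc(C(=O)Nc3cc(F)cc(F)c3)c(=O)c3ccc(N(C)C)nc32)ccc1OCCCCCCC[N+]1(C)CCN(C)CC1` gives 32%. Compound 3 thus stands second highest of the three, with compound 1 nearest and compound 2 furthest, as the steps of a number 11.2 percentage points higher from compound 1 to compound 3 (beyond the scatter) and a number 23 percentage points lower from compound 2 to compound 3 (beyond the scatter) show.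

Compound 4 `CC[N+]1(CCCCCCCOc2ccc(-n3cc(C(=O)Nc4cc(F)cc(F)c4)c(=O)c4ccc(N(C)C)nc43)cc2C)CCCC1` has not been measured. Its change from compound 3 is a group of 7 heavy atoms (6 carbon, 1 nitrogen; one five-membered non-aromatic ring with 1 hetero atom) in place of a group of 8 heavy atoms (6 carbon, 2 nitrogen; one six-membered non-aromatic ring with 2 hetero atoms), on a saturated chain carbon, seven bonds along the chain from an oxygen on an aromatic ring. The measured steps at this same position were a number 34.2 percentage points higher from compound 1 to compound 2 (beyond the scatter) and a number 11.2 percentage points higher from compound 1 to compound 3 (beyond the scatter), so exchanges of the head group have moved this read-out by modest to large amounts, in both directions relative to compound 3. For the measured compounds named here, no measured step involves a five-membered ring, so the direction is uncertain, and a step beyond the scatter in either direction is possible. Compound 4 is therefore expected to give about 40%, within roughly 22% to 58%, which means an expected step of a number 8 percentage points higher from compound 3 to compound 4 (within the scatter).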

Compound 4, a percentage reported as inhibition, at one concentration (the size of the read-out at that concentration, not a potency): 82.5%
For compound 4 the middle estimate is 42.5 percentage points below the measured one; the whole stated range lies below it.
By their numbers in this assay, from the lowest: compound 1; then compound 3; then compound 2; then compound 4.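

For the compounds shown here, the head group at the end of the chain matters more to this read-out than the earlier compounds showed: in this assay, the group with one five-membered non-aromatic ring gives a number 50.5 percentage points higher from compound 3 to compound 4 (beyond the scatter) and a number 61.7 percentage points higher from compound 1 to compound 4 (beyond the scatter). A non-aromatic head group can also exceed the aromatic six-membered ring of compound 2, with a number 27.5 percentage points higher from compound 2 to compound 4 (beyond the scatter) as the step, so compound 4 stands highest of the four, beyond the scatter of each of the others. No evidence is available to explain why this head group gives the highest number.

The compounds shown leave open whether the gain follows from the five-membered ring or from the ethyl on its charged nitrogen. They also do not show how a methyl in place of that ethyl, a six-membered ring with one nitrogen, or an uncharged tertiary amine at the chain end would read.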